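Pyridyl sulfone series: permeability notes toward compound 4

The source may hold more compounds than are shown below. What is called first, only, known or untested is meant among the compounds shown, and "the series" means these compounds.

Measured compounds:
compound 1 `CCCCc1[nH]c(=O)c(S(=O)(=O)c2ccc(-c3ccc(F)cc3)cc2)c(O)c1-c1c(OC)cccc1OC` — "not determined" (no result reported) in an ADME assay for permeability, using PAMPA, at pH 5.5; on this read-out higher numbers stand for higher permeability and lower numbers for lower permeability
compound 2 `CCCCc1[nH]c(=O)c(S(=O)(=O)c2ccc(-c3ccncc3C)cc2)c(O)c1-c1c(OC)cccc1OC` — 355 nm/s
compound 3 `CCCCc1[nH]c(=O)c(S(=O)(=O)c2ccc(-c3cccnc3OC)cc2)c(O)c1-c1c(OC)cccc1OC` — "not determined" (no result reported) in this assay

Compound 3 stands without a number: its entry in this assay reads "not determined" (no result reported). Compound 1 is in the same position, with "not determined" (no result reported). The only figure in the set is that of compound 2, which gives 355 nm/s in this assay. Going by the values given here, compound 1 and compound 3 therefore contribute nothing toward a comparison, and no step between measured compounds can be drawn.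

Compound 4 `CCCCc1[nH]c(=O)c(S(=O)(=O)c2ccc(-n3ccccc3=O)cc2)c(O)c1-c1c(OC)cccc1OC` is the next member. Its difference from compound 3 is a group of 7 heavy atoms (5 carbon, 1 nitrogen, 1 oxygen; one six-membered aromatic ring with 1 hetero atom) in place of a group of 8 heavy atoms (6 carbon, 1 nitrogen, 1 oxygen; one six-membered aromatic ring with 1 hetero atom), on an aromatic carbon, on an aromatic carbon of a six-membered aromatic ring of carbon only, para to a large group. Among the compounds with values here, without a value for compound 3 and with no related step in the set, the size and direction of this change in this assay cannot be read from the data; the one anchor is compound 2 at 355 nm/s.

Within the data shown here, the estimate for compound 4 in this assay is 120 nm/s, with an expected range from 30 nm/s to 350 nm/s, set somewhat under the single value in hand and wide to reflect that nothing ties compound 4 to a measured neighbour.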

Compound 4, apparent permeability: 177 nm/s
The estimate for compound 4 lay 1.5-fold (0.17 log units) below the measured number; low and high end bracket the measured number.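

In this assay, going by these compounds alone, the position on an aromatic carbon of a six-membered aromatic ring of carbon only, para to a large group, now has a second reading, and the step reads a 2.0-fold lower number from compound 2 to compound 4 (0.30 log units; within the scatter) in the only comparison available. The group in compound 4 carries an oxygen and a double bond outside aromatic rings that the group in compound 2 lacks, yet this exchange does not separate the two readings beyond the usual scatter, so the position tolerates both groups without a resolved difference on this read-out. No measurement among the data offers an explanation for this result.

The exchange of the 2-methoxypyridin-3-yl group for the group in compound 4 cannot be read, since compound 3 has no number, and compound 1 likewise offers no comparison. Going by these compounds, whether a morpholine or a carboxylic acid at this same place would give a reading in this assay apart from those of compound 2 and compound 4 remains open.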